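Dichlorophenyl replaces aminophenyl on the enone carbonyl

The source may hold more compounds than are shown below. What is called first, only, known or untested is meant among the compounds shown, and "the series" means these compounds.

Measured compounds:
compound 1, `COc1ccc(-c2cc(/C=C/C(=O)c3ccc(N)cc3)[nH]n2)cc1`, 5540 nM
compound 2, `COc1cc(-c2cc(/C=C/C(=O)c3ccc(N)cc3)[nH]n2)cc(OC)c1OC`, 6000 nM

The two measured compounds were tested in a functional assay on UO-31 cells (Homo sapiens) for inhibition, read by sulforhodamine B assay, with a stated time of 48 h; a higher number here means that more compound is tolerated, a lower number that less compound is tolerated. Compound 1 gives 5540 nM there, and compound 2 gives 6000 nM; the two numbers lie within the scatter of each other, so neither compound can be told apart from the other on this read-out. Compound 2 therefore stands on the same footing as compound 1, and no difference has been established between them.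

Compound 3, `COc1cc(-c2cc(/C=C/C(=O)c3ccc(Cl)c(Cl)c3)[nH]n2)cc(OC)c1OC`, has not yet been measured in this assay. It differs from compound 2 in one place: 3,4-dichlorophenyl in place of 4-aminophenyl on a carbonyl carbon. Among the compounds with values here, no pair of measured compounds shows a step of this kind, so there is no measured step to lean on. Compound 2 and compound 1 together give only a narrow spread of values, which offers no basis for a large shift in either direction. Compound 3 is therefore expected to land close to compound 2, with a step of a 1.2-fold lower number from compound 2 to compound 3 (0.08 log units; within the scatter) that is not beyond the scatter. The estimate for compound 3 is 5000 nM, in a range from 1800 nM to 14000 nM.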

Compound 3, concentration lethal to 50% of the cells: > 100000 nM
Compound 3 ended at the assay's limit (the forecaster's own chance of this, stated with the estimate: 15%); at least 20-fold (1.30 log units) between middle value and limit.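

Compounds 1 and 2 both carry 4-aminophenyl on the carbonyl carbon, so they said nothing about this position; replacing that group with 3,4-dichlorophenyl gives an at least 16-fold higher number from compound 2 to compound 3 (1.22 log units; beyond the scatter) in this assay, which shows that the group held here strongly changes how much compound is tolerated. In this assay, compound 3 reads > 100000 nM, which is a limit of the assay and not a number. The step therefore fixes only the least size of the change, and its full size cannot be read, because the value is a limit: the limit of > 100000 nM in this assay, at which 1 of the 3 values shown sits.

The compounds shown cannot separate the loss of the amine from the arrival of the two chlorine atoms as the source of the step; a plain phenyl, a phenyl with a single chlorine or a 4-hydroxyphenyl on the same carbonyl carbon would bear on that question. Within the data shown here, whether 3,4-dichlorophenyl has the same effect with the single methoxy group of compound 1 also stays open, since the step is seen only with the trimethoxy pattern of compound 2.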